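The source may hold more compounds than are shown below. What is called first, only, known or untested is meant among the compounds shown, and "the series" means these compounds.

Measured so far:
compound 1 `CC1(C)[C@@H]2CC[C@@]1(CS(=O)(=O)N1CCN(c3ncccc3C(F)(F)F)CC1)C(=O)C2`: > 31600 nM
compound 2 `CC1(C)[C@@H]2CC[C@@]1(CS(=O)(=O)NC1CCN(c3ccc(C(F)(F)F)cn3)CC1)C(=O)C2`: 15800 nM

In a functional assay on CHO-K1 cells for antagonist activity at C-X-C chemokine receptor type 3 (Homo sapiens), read by FLIPR and calcium flux (a lower number here means a stronger inhibitor, a higher number a weaker inhibitor), compound 1 gives > 31600 nM, which is a limit of the assay rather than a number, so compound 1 stands only at the edge of what was measured, as the limit of > 31600 nM in this assay, at which 1 of the 2 values shown sits, shows. In this assay, going by the values given here, compound 2 gives 15800 nM; no step between compound 1 and compound 2 is computed, and the two values show only that both are weak inhibitors. Compound 3 `CC1(C)[C@@H]2CC[C@@]1(CS(=O)(=O)N1CCN(c3cc4ccccc4cn3)CC1)C(=O)C2` has not yet been measured. It differs from compound 1 by isoquinolin-3-yl in place of 3-(trifluoromethyl)pyridin-2-yl on an amine nitrogen in a ring. Among the compounds with values here, with no measured step to lean on, the step of an at least 1.5-fold lower number from compound 1 to compound 3 (0.19 log units; that floor lies within the scatter) is expected to stay within the scatter. Compound 3 is therefore estimated at 20000 nM, within 6000 nM to 60000 nM.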

Compound 3, half-maximal inhibitory concentration: 15800 nM
Compound 3: the middle estimate sits 1.3-fold (0.10 log units) above what was measured; the range from low to high includes it.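

In this assay the amine nitrogen in a ring carries isoquinolin-3-yl in compound 3, which gives 15800 nM as a number rather than a limit. The change from 3-(trifluoromethyl)pyridin-2-yl is an at least 2.0-fold lower number from compound 1 to compound 3 (0.30 log units; that floor lies within the scatter) and can be read only as a floor. Compound 1 stands at a limit of the assay: the limit of > 31600 nM in this assay, at which 1 of the 3 values shown sits.

The compounds shown leave open how far compound 1 truly lies from compound 3. They also leave open whether a quinolin-2-yl group at this place, or an amine or a carboxylic acid on the isoquinoline, would move the number beyond the scatter.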